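The source may hold more compounds than are shown below. What is called first, only, known or untested is meant among the compounds shown, and "the series" means these compounds.

Measured in a functional assay on MCF7 cells (Homo sapiens) for antiproliferative activity, read by MTT assay, with a stated time of 48 h; on this read-out lower numbers stand for stronger inhibition and higher numbers for weaker inhibition:
Compound 1 `CCCCCCCn1cc(COC[C@@H]2OC[C@H](N)[C@@H]2O)nn1`: > 128000 nM, a limit
Compound 2 `CCCCCCCCCCn1cc(COC[C@@H]2OC[C@H](N)[C@@H]2O)nn1`: 9640 nM
Compound 3 `CCCCCCCn1cc(COC[C@@H]2OC[C@H](N)[C@H]2O)nn1`: > 128000 nM, a limit

Compound 3 offers no number to start from. The record for compound 3 is > 128000 nM, and that is a limit. Its standing is therefore (the limit of > 128000 nM in this assay, at which 2 of the 3 values shown sit).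

Compound 4 `CCCCCCCCCCCCCCCCn1cc(COC[C@@H]2OC[C@H](N)[C@H]2O)nn1` departs from compound 3 by one change: nonyl in place of hydrogen on a saturated chain carbon, seven bonds along the chain from an aromatic nitrogen. In words, this is nonyl in place of hydrogen on a saturated chain carbon, seven bonds along the chain from an aromatic nitrogen. Cut one bond further out, it reads methyl to decyl.

The closest guide is an at least 13-fold lower number from compound 1 to compound 2 (1.12 log units; beyond the scatter), a large change beyond the scatter, made by propyl in place of hydrogen at that same place. The other measured step, a step that the two limits leave unreadable from compound 1 to compound 3, gives no size, and the fact that compounds 1 and 3 differ only in the configuration as drawn is all it records. No such chain change has been measured on the configuration of compound 3, so the guide carries over with some uncertainty. A large step towards lower numbers is nevertheless expected in this assay. For compound 4 the estimate is 8000 nM, with an expected range from 2000 nM to 32000 nM. The step this estimate implies is an at least 16-fold lower number from compound 3 to compound 4 (1.20 log units; beyond the scatter).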

Compound 4, half-maximal inhibitory concentration: 2260 nM
Compound 4: the middle estimate sits 3.5-fold (0.55 log units) above what was measured; the range from low to high includes it.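

In this assay, nonyl in place of hydrogen on a saturated chain carbon, seven bonds along the chain from an aromatic nitrogen, gives an at least 56-fold lower number from compound 3 to compound 4 (1.75 log units; beyond the scatter). Until now, a chain change at this place had been read only on the configuration of compound 1, as an at least 13-fold lower number from compound 1 to compound 2 (1.12 log units; beyond the scatter), whereas this result shows that a longer chain also brings a measurable value on the configuration of compound 3. Compound 3, the start of this step, stands at a limit, so the step has a lower bound and no exact size: the limit of > 128000 nM in this assay, at which 2 of the 4 values shown sit.

The compounds shown leave open how the two configurations compare, since the only pair that differs in configuration alone gives limits on both sides: the fact that compounds 1 and 3 differ only in the configuration as drawn Also open is whether a longer chain than that of compound 4, or an amine or a carboxylic acid in place of the nonyl group, would carry a step of this kind in this assay.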